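The source may report more compounds than this note shows. Statements on the series, on what has been measured and on what is new or still open speak of the compounds shown alone.

Compounds measured in a functional assay on CCRF-CEM cells (Homo sapiens) for antiproliferative activity, read by cell counting, with a stated time of 96 h; on this read-out higher numbers stand for weaker inhibition and lower numbers for stronger inhibition:
Compound 1 `CC(Nc1ccccc1Oc1ccc(Cl)cc1)=C1C(=O)CC(c2ccccc2)CC1=O` gives 190 nM.
Compound 2 `COc1ccc(Oc2ccccc2NC(C)=C2C(=O)CC(c3ccccc3)CC2=O)cc1` gives 120 nM.
Compound 3 `COc1cc(Oc2ccccc2NC(C)=C2C(=O)CC(c3ccccc3)CC2=O)ccc1N` gives 12 nM.

Compound 3 has the lowest number of the three, with a 10-fold lower number from compound 2 to compound 3 (1.00 log units; beyond the scatter) and a 16-fold lower number from compound 1 to compound 3 (1.20 log units; beyond the scatter), both beyond the scatter. Compound 4 `CC(Nc1ccccc1Oc1cccc(N)c1)=C1C(=O)CC(c2ccccc2)CC1=O` differs from compound 3 by 3-aminophenyl in place of 4-amino-3-methoxyphenyl on an oxygen on an aromatic ring. The steps of a 16-fold lower number from compound 1 to compound 3 (1.20 log units; beyond the scatter) and a 10-fold lower number from compound 2 to compound 3 (1.00 log units; beyond the scatter) both end at the 4-amino-3-methoxyphenyl group that compound 4 gives up, whereas a 1.6-fold lower number from compound 1 to compound 2 (0.20 log units; within the scatter) lies within the scatter. Because a 10-fold lower number from compound 2 to compound 3 (1.00 log units; beyond the scatter) was large, losing that group in compound 4 is expected to raise the number, though the retained amino group may keep part of the gain. Compound 4 is therefore estimated at 60 nM, within 20 nM to 200 nM, a step of a 5.0-fold higher number from compound 3 to compound 4 (0.70 log units; beyond the scatter).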

Compound 4, half-maximal inhibitory concentration: 42 nM
Compound 4: the middle estimate sits 1.4-fold (0.15 log units) above what was measured; the measured number falls inside the stated range.
By their numbers in this assay, from the lowest: compound 3; then compound 4; then compounds 2 and 1 (each within the scatter of the next).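

Replacing 4-amino-3-methoxyphenyl with 3-aminophenyl on this oxygen raises the number only modestly (a 3.5-fold higher number from compound 3 to compound 4 (0.54 log units; beyond the scatter)), so an aminophenyl without the methoxy group keeps part of the gain. Compound 4 still stands clear of both compounds without an amino group (a 2.9-fold lower number from compound 2 to compound 4 (0.46 log units; beyond the scatter); a 4.5-fold lower number from compound 1 to compound 4 (0.66 log units; beyond the scatter)). Nothing measured here accounts for these differences.

Since the step from compound 3 to compound 4 changes both the methoxy group and the amino group's place, their shares remain unseparated. Going by these compounds, whether a dimethylamino or acetamido group could replace the amino group remains open.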